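The source may report more compounds than this note shows. Statements on the series, on what has been measured and on what is new or still open speak of the compounds shown alone.

Of the compounds shown here, two have been measured in an ADME assay on microsomes from liver (Homo sapiens) for metabolic stability; on this read-out higher numbers stand for fast clearance and lower numbers for slow clearance. Compound 1 `CN(C)c1noc(-c2cccc(CN(C)c3ccc4[nH]nc(C(=O)O)c4c3)c2O)n1` gives 14 mL/min/kg, while compound 2 `CN(C)c1noc(-c2cccc(CNc3ccc4[nH]nc(C(=O)O)c4c3)c2)n1` gives 0.5 mL/min/kg, the lower of the two numbers, and the gap between them lies beyond the usual scatter. Compound 3 `CN(C)c1noc(-c2cccc(CNc3ccc4[nH]nc(C(=O)O)c4c3)c2Cl)n1` differs from compound 2 in one place: chloro in place of hydrogen on an aromatic carbon. Among the measured compounds shown here, no measured pair isolates this change, so only a small rise, within the scatter, is expected: the estimated step is a 1.8-fold higher number from compound 2 to compound 3 (0.26 log units; within the scatter). For compound 3, the expected clearance is 0.9 mL/min/kg, with an estimated range of 0.3 mL/min/kg to 3.5 mL/min/kg.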

Compound 3, clearance in the Homo sapiens assay: 5.8 mL/min/kg
Estimate against measurement, compound 3: 6.4-fold (0.81 log units) below; measured number outside the range, above it.
By their numbers in the Homo sapiens assay, from the lowest: compound 2; then compound 3; then compound 1.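

In the Homo sapiens assay, compound 2 gives 0.5 mL/min/kg and compound 3 gives 5.8 mL/min/kg. In the Homo sapiens assay, chloro in place of hydrogen, ortho to a 3-(dimethylamino)-1,2,4-oxadiazol-5-yl group, gives a 12-fold higher number from compound 2 to compound 3 (1.06 log units; beyond the scatter), so a single added heavy atom at this place on the ring can matter a great deal. In a physicochemical assay for solubility, measured as kinetic solubility, at pH 7.4 (on this read-out lower numbers stand for lower solubility and higher numbers for higher solubility), compound 2 gives 255000 nM and compound 3 gives 296000 nM. In the physicochemical assay the same change gives a 1.2-fold higher number from compound 2 to compound 3 (0.06 log units; within the scatter), which leaves the two compounds level on solubility. Nothing shown here gives a reason for the step in clearance. As far as these compounds go, whether fluoro, methyl or a nitrile at this place would give a step of similar size stays open, as does the effect of chloro on another carbon of this ring.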